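This account rests on a few compounds, and the source may have more. Where it says the series, first, only, none or still open, it means among the compounds named here.

Compound 1 `CCOS(=O)(=O)/C=C/c1ccc(O[C@@H]2CN(C(=O)C(=O)Nc3ccccc3)C[C@@H]2Oc2ccc(CCS(=O)(=O)OCC)cc2)cc1` — an ADME assay for permeability, using PAMPA, with a stated time of 12 h, at pH 7.4, tested at 10 uM (on this read-out higher numbers stand for higher permeability and lower numbers for lower permeability), 1.09 10^-6 cm/s
Compound 2 `CCCCCCCCCCc1ccc(NC(=O)C(=O)N2C[C@H](Oc3ccc(CCS(=O)(=O)OCC)cc3)[C@H](Oc3ccc(/C=C/S(=O)(=O)OCC)cc3)C2)cc1` — this assay 1.82 10^-6 cm/s

Among the compounds with values here, compound 2 gives the higher of the two numbers, with compound 1 nearest; the single measured step, a 1.7-fold higher number from compound 1 to compound 2 (0.22 log units; within the scatter), lies within the scatter. Compound 3 `CCCCCCCCCCCCc1ccc(NC(=O)C(=O)N2C[C@H](Oc3ccc(CCS(=O)(=O)OCC)cc3)[C@H](Oc3ccc(/C=C/S(=O)(=O)OCC)cc3)C2)cc1` differs from compound 2 in one place: ethyl in place of hydrogen on a saturated chain carbon, ten or more bonds along the chain from an aromatic carbon. Only the decyl-for-hydrogen step bears on this change, and it produced no movement beyond the scatter; lengthening that chain by ethyl is expected to do the same, a 1.1-fold higher number from compound 2 to compound 3 (0.04 log units; within the scatter). Compound 3 is therefore estimated at 2 10^-6 cm/s, with a range from 1 10^-6 cm/s to 4 10^-6 cm/s.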

Compound 3, apparent permeability: 2.26 10^-6 cm/s
The estimate for compound 3 lay 1.1-fold (0.05 log units) below the measured number; measured number inside the range.
By their numbers in this assay, from the lowest: compounds 1, 2 and 3 (each within the scatter of the next, the first and the last beyond it).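

At this saturated chain carbon, ethyl in place of hydrogen leaves compound 3 not separated from compound 2 in this assay (a 1.2-fold higher number from compound 2 to compound 3 (0.09 log units; within the scatter)). Dodecyl in place of hydrogen on an aromatic carbon gives the first step in the series beyond the scatter, though only a modest one (a 2.1-fold higher number from compound 1 to compound 3 (0.32 log units; beyond the scatter)), whereas decyl stayed within it. No measurement on hand accounts for either step.

With only decyl and dodecyl at this position, no trend with chain length can be claimed. As far as these compounds go, whether a longer chain, or an amine or a carboxylic acid in place of dodecyl, would shift the number remains open.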